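This account rests on a few compounds, and the source may have more. Where it says the series, first, only, none or still open, it means among the compounds named here.

Compound 3 `Cc1cnc2nc(-c3ccc(Cl)cc3)cc(O)c2c1` gives 2400 nM in a functional assay on SF-295 cells (Homo sapiens); on this read-out higher numbers stand for weaker inhibition of growth and lower numbers for stronger inhibition of growth. Compound 1 `Oc1cc(-c2ccc(Cl)cc2)nc2ncccc12` differs from it by hydrogen in place of methyl on an aromatic carbon, and in this assay compound 1 gives 40700 nM; the step of a 17-fold higher number from compound 3 to compound 1 (1.23 log units; beyond the scatter). Among the compounds with values here, compound 2 `COc1ccc(-c2cc(O)c3c(C)cc(C)nc3n2)cc1` gives 42700 nM in this assay, a number within the scatter of compound 1; how its core differs from that of compound 3 is not broken down here, and the two values show only that compound 3 sits far lower. Compound 4 `COc1ccc(-c2cc(O)c3ccc(C)nc3n2)cc1` arises from compound 2 by hydrogen in place of methyl on an aromatic carbon, the same kind of change as that from compound 3 to compound 1, but at a place ortho to a fused ring, meta to a methyl group and opposite the ring nitrogen, rather than two atoms from the ring nitrogen and para to a fused ring. The step of a 17-fold higher number from compound 3 to compound 1 (1.23 log units; beyond the scatter) raised the number greatly. For compound 4 a smaller step in the same direction is estimated, a 1.9-fold higher number from compound 2 to compound 4 (0.27 log units; within the scatter), the place of the change not being the same. Compound 4 is thus expected to give about 80000 nM, between 30000 nM and 250000 nM.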

Compound 4, concentration for 50% growth inhibition: 89100 nM
The estimate for compound 4 lay 1.1-fold (0.05 log units) below the measured number, and the stated range covers the measured number.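

Hydrogen in place of methyl on an aromatic carbon gave a 2.1-fold higher number from compound 2 to compound 4 (0.32 log units; beyond the scatter) in this assay, a modest step in the same direction as the earlier one. The direction of the change carried over between these two cores, but its size did not: the same change on two cores in this assay, a 17-fold higher number (1.23 log units; beyond the scatter) from compound 3 to compound 1 and a 2.1-fold higher number (0.32 log units; beyond the scatter) from compound 2 to compound 4, 8.1-fold (0.91 log units) apart, beyond the scatter of two such steps

The two pairs differ both in the place of the change and in the rest of the core, and they do not show which of these sets the size of the step, nor do two pairs establish a rule for the series.

As far as these compounds go, it remains open how the step would compare if made at one same place on both cores. From the compounds shown here alone, it also remains open how an ethyl group, an amine or a carboxylic acid at these places would read in this assay.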